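A few compounds are considered here, and "the series" means these few. Any claim that something is new, unique, unknown or untested is made for them only; others in the source may bear on it.

Compound 2 `CN1C(=O)C(CCNc2cccnc2)COC12C=CC(=O)C=C2` stands in an assay on isolated protein for inhibition of N-lysine methyltransferase SMYD2 (Homo sapiens), read by filter binding, with a stated time of 1 h (on this read-out higher numbers stand for weaker inhibition and lower numbers for stronger inhibition), with only a limit of the assay and no number. In this assay compound 2 gives > 20000 nM, which is the limit of > 20000 nM in this assay, at which 1 of the 2 values shown sits. Compound 1 `CN1C(=O)C(CCO)COC12C=CC(=O)C=C2`, which carries a hydroxy where compound 2 carries the (pyridin-3-yl)amino, also reaches only a limit of the assay. In this assay compound 1 gives > 30000 nM, which is the limit of > 30000 nM in this assay, at which 1 of the 2 values shown sits. Going by the values given here, the one measured step, a step that the two limits leave unreadable from compound 1 to compound 2, is thus of unreadable size and gives no direction. Compound 3 `CN1C(=O)C(CCNc2ccc(F)cc2)COC12C=CC(=O)C=C2` has not yet been measured in this assay. It differs from compound 2 by 4-fluorophenyl in place of pyridin-3-yl on an amine nitrogen. Among the compounds with values here, no measured step touches the group on the amine nitrogen, so nothing speaks for a step beyond the scatter in either direction. Compound 3 is therefore expected to sit near the limits as well, with the step that the limit leaves unreadable from compound 2 to compound 3 estimated as none beyond the scatter. The estimate for compound 3 in this assay is 25000 nM, expected within 5000 nM to 100000 nM.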

Compound 3, half-maximal inhibitory concentration: 11600 nM
For compound 3 the middle estimate is 2.2-fold (0.33 log units) above the measured one; the range from low to high includes it.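

Compound 3 is the only compound shown that gives a number rather than a limit in this assay, so a measurable read-out is reached with 4-fluorophenyl on the amine nitrogen. Set against the hydroxy of compound 1, the (4-fluorophenyl)amino on the saturated chain carbon gives an at least 2.5-fold lower number from compound 1 to compound 3 (0.41 log units; beyond the scatter), which shows that this chain position can register a change. The exchange of pyridin-3-yl for 4-fluorophenyl on the amine nitrogen gives an at least 1.7-fold lower number from compound 2 to compound 3 (0.23 log units; that floor lies within the scatter), so this exchange alone is not shown to matter.

From the compounds shown here alone, whether an unsubstituted phenyl, a 4-chlorophenyl or a benzyl on the amine nitrogen would lower the number further remains open. Going by these compounds, the true size of the step from the pyridin-3-yl compound also remains open, because compound 2 reaches only a limit: the limit of > 20000 nM in this assay, at which 1 of the 3 values shown sits.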